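A few compounds are considered here, and "the series" means these few. Any claim that something is new, unique, unknown or untested is made for them only; others in the source may bear on it.

Measured compounds in this set:

compound 1 `Cc1nnsc1CO/N=C/c1c(C)nn(C)c1Oc1ccc(Br)cc1` — 11800 nM
compound 2 `Cc1nnsc1CO/N=C/c1c(C)nn(C)c1Oc1ccc(C(C)(C)C)cc1` — > 50000 nM, a limit of the assay
compound 3 `Cc1nnsc1CO/N=C/c1c(C)nn(C)c1Oc1cccc(F)c1F` — 10200 nM

In a functional assay on Huh-7 cells (Homo sapiens) for inhibition, read by MTT assay, with a stated time of 48 h (on this read-out lower numbers stand for stronger inhibition and higher numbers for weaker inhibition), compound 1 gives 11800 nM, the higher of the two numbers reported as numbers. Compound 3 gives 10200 nM, and the step of a 1.2-fold lower number from compound 1 to compound 3 (0.06 log units; within the scatter) lies within the scatter, so no order between the two can be read. Compound 2 stands at the limit (the limit of > 50000 nM in this assay, at which 1 of the 3 values shown sits), where its value > 50000 nM is a limit of the assay and not a number. The step of an at least 4.2-fold higher number from compound 1 to compound 2 (0.62 log units; beyond the scatter) is the only one here that goes beyond the scatter.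

Compound 4 `Cc1nnsc1CO/N=C/c1c(C)nn(C)c1Cl` differs from compound 1 in that (chloro in place of 4-bromophenoxy on an aromatic carbon). Neither measured step bears directly on this change: the steps from compound 1 to compound 2 and from compound 1 to compound 3 both swap substituents on the phenyl ring, while here the whole 4-bromophenoxy group leaves and a single chloro atom enters. The step from compound 1 to compound 2 shows that changes at this position can move the number beyond the scatter, in the direction of weaker inhibition, and that is the only direction seen. Compound 4 is therefore expected to show a step of a 1.5-fold higher number from compound 1 to compound 4 (0.18 log units; within the scatter) toward a higher number, modest in size. The estimate for compound 4 in this assay is 18000 nM, with a range from 6000 nM to 50000 nM.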

Compound 4, half-maximal inhibitory concentration: > 50000 nM
Compound 4 ended at the assay's limit; the forecaster's own chance of this, stated with the estimate: 30%; at least 2.7-fold (0.44 log units) between middle value and limit.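

In this assay, chloro in place of 4-bromophenoxy on this aromatic carbon gives an at least 4.2-fold higher number from compound 1 to compound 4 (0.62 log units; beyond the scatter), and this is the first change shown that removes the whole group from that carbon instead of altering the phenyl ring it carries. For compound 4, the value > 50000 nM is a limit of the assay and not a number, so the step gives only a lower bound on the size of the change. Among the compounds shown, only compound 1 and compound 3, each with a substituted phenoxy group at this place, give numbers, yet compound 2 keeps a phenoxy group with tert-butyl and still reaches the same limit, so both a change on the phenyl ring and the loss of the whole group end there: the limit of > 50000 nM in this assay, at which 2 of the 4 values shown sit.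

On these data alone, what stays open is whether a smaller group on this carbon, such as methoxy or an amine, would give a number, and thus whether the phenyl ring or the oxygen accounts for the difference. The two limits also leave no order between compound 2 and compound 4 to be read.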